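Carbamate aryl exchange: compound 3 to compound 4

This account rests on a few compounds, and the source may have more. Where it says the series, first, only, none or still open, it means among the compounds named here.

Compound 3 `CC(C)c1cccc(C(C)C)c1OS(=O)(=O)NC(=O)Oc1cccnc1` stands at the limit of an assay on liver for inhibition of sterol O-acyltransferase 1 (Rattus norvegicus), using microsomes; on this read-out higher numbers stand for weaker inhibition and lower numbers for stronger inhibition. In this assay compound 3 gives > 50000 nM, which is a limit of the measurement and not a number; one of the three values in the set rests there (the limit of > 50000 nM in this assay, at which 1 of the 3 values shown sits). Compound 2 `CC(C)c1cccc(C(C)C)c1OS(=O)(=O)NC(=O)O[C@@H]1C[C@H](C)CCC1C(C)C` gives 21000 nM in this assay, so the step of an at least 2.3-fold higher number from compound 2 to compound 3 (0.37 log units; beyond the scatter) can be read only as a bound, with the true gap possibly larger. Within the data shown here, compound 1 `CC(C)CN(CC(C)C)S(=O)(=O)NC(=O)Nc1c(C(C)C)cccc1C(C)C` gives 420 nM in this assay; it differs from compound 3 and from compound 4 in more than one place and so supplies no single step here.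

Compound 4 `Cc1cccc(C)c1OC(=O)NS(=O)(=O)Oc1c(C(C)C)cccc1C(C)C` differs from compound 3 as follows: 2,6-dimethylphenyl in place of pyridin-3-yl on an oxygen next to a carbonyl group. Among the measured compounds shown here, the only measured step at this oxygen, an at least 2.3-fold higher number from compound 2 to compound 3 (0.37 log units; beyond the scatter), ran toward weaker inhibition when pyridin-3-yl entered; compound 4 removes that group again but brings in 2,6-dimethylphenyl, a ring not yet tried at this position, so the size of any return is open. Compound 4 is expected to move back toward the number of compound 2, a step of an at least 2.5-fold lower number from compound 3 to compound 4 (0.39 log units; beyond the scatter), while a limit read-out remains a real possibility. The estimate for compound 4 in this assay is 20000 nM, with a range from 5000 nM to 60000 nM.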

Compound 4, half-maximal inhibitory concentration: > 50000 nM
Compound 4 gave a limit, no number; the forecaster's own chance of this, stated with the estimate: 35%; at least 2.5-fold (0.39 log units) between middle value and limit.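

Exchanging 2-isopropyl-5-methylcyclohexyl for 2,6-dimethylphenyl on an oxygen next to a carbonyl group gives, in this assay, an at least 2.3-fold higher number from compound 2 to compound 4 (0.37 log units; beyond the scatter), which runs in the same direction as the change to pyridin-3-yl, an at least 2.3-fold higher number from compound 2 to compound 3 (0.37 log units; beyond the scatter). Among the compounds shown, the weaker inhibition at this position therefore does not depend on the ring nitrogen of pyridin-3-yl, since a ring of carbon only also gives a step toward weaker inhibition, and no compound shown goes against this. The step between compound 3 and compound 4 cannot be read and the two aromatic rings cannot be ranked, as both values are limits of the measurement and not numbers: the limit of > 50000 nM in this assay, at which 2 of the 4 values shown sit.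

From the compounds shown here alone, how far either compound lies past its limit stays open, so both steps from compound 2 remain bounds and not sizes. Going by these compounds, it also stays open whether a plain cyclohexyl, an unsubstituted phenyl or a longer alkyl chain on this oxygen would return a measurable number, and compound 1 differs in more than one place and cannot settle this.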